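The source may hold more compounds than are shown below. What is called first, only, known or untested is meant among the compounds shown, and "the series" means these compounds.

Compound 1 `Cc1ccc(S(=O)(=O)NC(=O)/C=C/c2ccccc2)cc1` is the starting point; in a functional assay on B16-F10 cells (Mus musculus) for antiproliferative activity, read by ELISA and MTT assay, with a stated time of 48 h (on this read-out higher numbers stand for weaker inhibition and lower numbers for stronger inhibition), compound 1 gives 13.8 ug/mL. Compound 2 `O=C(/C=C/c1ccccc1)NS(=O)(=O)c1ccc(F)cc1` differs from it in one place, (fluoro in place of methyl on an aromatic carbon), and in this assay compound 2 gives 2.1 ug/mL, so that a 6.6-fold lower number from compound 1 to compound 2 (0.82 log units; beyond the scatter). Compound 3 `Cc1ccc(S(=O)(=O)NC(=O)/C=C/c2ccc(F)cc2)cc1` carries its change on the other ring, (fluoro in place of hydrogen on an aromatic carbon); in this assay compound 3 gives 4.8 ug/mL, and a 2.9-fold lower number from compound 1 to compound 3 (0.46 log units; beyond the scatter). Compound 4 `O=C(/C=C/c1ccc(F)cc1)NS(=O)(=O)c1ccc(F)cc1` has not yet been measured. It stands to compound 3 exactly as compound 2 stands to compound 1: fluoro in place of methyl on an aromatic carbon, the same change at the same kind of place, while the cores of compound 3 and compound 1 differ only by the fluorine already described. Among the measured compounds shown here, only one measured instance of this change exists, a 6.6-fold lower number from compound 1 to compound 2 (0.82 log units; beyond the scatter), so any expectation rests on a single step. In this assay an expected step of a 5.3-fold lower number from compound 3 to compound 4 (0.73 log units; beyond the scatter) is taken, somewhat tempered because a 6.6-fold lower number from compound 1 to compound 2 (0.82 log units; beyond the scatter) was seen on a core without the second fluorine. Compound 4 is therefore estimated at 0.9 ug/mL, with a plausible span from 0.4 ug/mL to 2.5 ug/mL.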

Compound 4, half-maximal inhibitory concentration: 0.8 ug/mL
Estimate against measurement, compound 4: 1.1-fold (0.05 log units) above; measured number inside the range.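

In this assay, replacing 4-methylphenyl by 4-fluorophenyl gave a 6.0-fold lower number from compound 3 to compound 4 (0.78 log units; beyond the scatter), and the change carried over from the core of compound 1 to the fluorinated core with its size intact: the same change on two cores in this assay, a 6.6-fold lower number (0.82 log units; beyond the scatter) from compound 1 to compound 2 and a 6.0-fold lower number (0.78 log units; beyond the scatter) from compound 3 to compound 4, 1.1-fold (0.04 log units) apart, within the scatter of two such steps. Fluoro in place of hydrogen on the other ring gave a 2.6-fold lower number from compound 2 to compound 4 (0.42 log units; beyond the scatter), and this change also held its size when moved to a second core: the same change on two cores in this assay, a 2.9-fold lower number (0.46 log units; beyond the scatter) from compound 1 to compound 3 and a 2.6-fold lower number (0.42 log units; beyond the scatter) from compound 2 to compound 4, 1.1-fold (0.04 log units) apart, within the scatter of two such steps. Within these four compounds, each change therefore gave much the same step whichever form the other ring took, but each comparison rests on only two cores in a single assay, so this shows neither why the steps agree nor that they would hold on cores beyond these.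

The compounds shown leave open whether chloro, methoxy or a nitrile in place of the fluoro would give steps of similar size. They also leave open whether the steps would persist with a methyl group on the amide nitrogen.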